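Chlorine added to the core of a benzyl series

A few compounds are considered here, and "the series" means these few. Any claim that something is new, unique, unknown or untested is made for them only; others in the source may bear on it.

Three measured compounds share one core and differ in where the chloromethyl group sits on the benzyl ring. Compound 1 `ClCc1ccccc1Cn1cnc2c(Cl)ncnc21` and compound 3 `ClCc1cccc(Cn2cnc3ncnc(Cl)c32)c1` carry numbers in a functional assay on HCT-116 cells (Homo sapiens) for cytotoxicity, read by sulforhodamine B assay, with a stated time of 48 h; on this read-out higher numbers stand for lower toxicity in this test and lower numbers for higher toxicity in this test; compound 2 `ClCc1ccc(Cn2cnc3ncnc(Cl)c32)cc1` does not. In this assay compound 1 gives 7080 nM, and in the same assay compound 3 gives 9540 nM; the two values lie within the usual scatter of each other, so no order between them can be read. In this assay compound 2 is recorded as "not determined" (no result reported), and nothing on hand says whether it sits with compounds 1 and 3 or apart from them.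

Compound 4 `ClCc1ccc(Cn2cnc3nc(Cl)nc(Cl)c32)cc1` is the next compound. It differs from compound 2 in one place: chloro in place of hydrogen on an aromatic carbon. Going by the values given here, no measured pair shows what this chloro in place of hydrogen does, so the size and direction of the step in this assay are open; a change of no more than the scatter is as plausible as a shift either way. The working expectation for compound 4 in this assay is 8000 nM, estimated to fall between 2500 nM and 25000 nM, anchored to the values of compounds 1 and 3 in the absence of a number for compound 2.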

Compound 4, concentration lethal to 50% of the cells: > 100000 nM
Compound 4: only a limit was reported; the forecaster's own chance of this, stated with the estimate: 15%; at least 12-fold (1.09 log units) between middle value and limit.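

No step can be read between compound 2, which carries no number in this assay, and compound 4. Compound 4 gives only a limit, > 100000 nM. The compounds shown leave open what chloro in place of hydrogen does on this core, and whether compound 2 sits with compound 1 and compound 3 or apart from them.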